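Taking the selenium-bearing chain off compound 3

The source may hold more compounds than are shown below. What is called first, only, known or untested is meant among the compounds shown, and "the series" means these compounds.

Values in a functional assay on LoVo cells (Homo sapiens) for inhibition, read by MTT assay, with a stated time of 48 h; a higher number here means a weaker inhibitor, a lower number a stronger inhibitor:
Compound 1 `COc1ccc(N(C)c2nc(C)nc3ccccc23)cc1OCCCCCC[Se]C#N`: 8580 nM
Compound 2 `Cc1nc(N(C)c2ccc(OCC[Se]C#N)cc2)c2ccccc2n1`: 547 nM
Compound 3 `COc1ccc(N(C)c2nc(C)nc3ccccc23)cc1OCCCC[Se]C#N`: 882 nM

Compound 3 sits well under compound 1 on these numbers, while its gap to compound 2 lies within the usual scatter. The next compound, compound 4 `COc1ccc(N(C)c2nc(C)nc3ccccc23)cc1`, is compound 3 with its whole side chain gone: a hydrogen atom in place of a group of 8 heavy atoms (5 carbon, 1 nitrogen, 1 oxygen, 1 selenium; no ring), on an aromatic carbon. The change sits on an aromatic carbon of a six-membered aromatic ring of carbon only, ortho to a methoxy group.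

Among the measured compounds shown here, only one measured step bears on this. Shortening the chain gave a 9.7-fold lower number from compound 1 to compound 3 (0.99 log units; beyond the scatter), which is beyond the scatter. Removing the group altogether goes further in the same direction, so a lower number is expected, in a step of similar or greater size. For the measured compounds named here, this is thin evidence, since no measured compound lacks the chain entirely, and the range is wide. The estimate amounts to an 18-fold lower number from compound 3 to compound 4 (1.25 log units; beyond the scatter), an expected fall in this assay. For compound 4 the expected value is 50 nM, with an estimated range of 5 nM to 500 nM.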

Compound 4, half-maximal inhibitory concentration: 8 nM
For compound 4 the middle estimate is 6.3-fold (0.80 log units) above the measured one, within the range that was stated.
By their numbers in this assay, from the lowest: compound 4; then compounds 2 and 3 (each within the scatter of the next); then compound 1.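

Until now every compound carried a selenium-bearing chain, so only chain length could be compared; the bare compound gives a 110-fold lower number from compound 3 to compound 4 (2.04 log units; beyond the scatter) in this assay and makes clear that a chain is not needed for a low number. The same replacement by hydrogen reads as a 68-fold lower number from compound 2 to compound 4 (1.83 log units; beyond the scatter) and as a 1100-fold lower number from compound 1 to compound 4 (3.03 log units; beyond the scatter) in the same assay, so among these compounds hydrogen gives a lower number than every chain, with no compound going against this. Nothing shown explains why the chain costs so much here.

The compounds shown leave open whether the higher numbers go with the selenium and nitrile end or with the chain itself. A plain hexyl chain or a small ethoxy group on that aromatic carbon could tell these apart, by landing nearer compound 4 or nearer compound 3.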